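This account rests on a few compounds, and the source may have more. Where it says the series, first, only, none or still open, it means among the compounds named here.

- compound 1 `CCCCCC(=O)NCc1ccc(C(=O)N[C@H](C(=O)O)[C@@H](C)CC)cc1` gives > 1500 ug/mL
- compound 2 `CCCCCCCCCCCC(=O)NCc1ccc(C(=O)N[C@H](C(=O)O)[C@@H](C)CC)cc1` gives 400 ug/mL

In a toxicity assay on cells (Erythrocyte, Homo sapiens) for cytotoxicity, read by hemolysis (on this read-out lower numbers stand for an effect already at smaller amounts and higher numbers for an effect only at larger amounts of compound), compound 1 gives > 1500 ug/mL, which is a limit of the assay and not a number. Compound 1 therefore stands at the limit of > 1500 ug/mL in this assay, at which 1 of the 2 values shown sits.

Compound 3 `CCCCCCCCCCCCCCCCCC(=O)NCc1ccc(C(=O)N[C@H](C(=O)O)[C@@H](C)CC)cc1` has not yet been measured. It differs from compound 1 by dodecyl in place of hydrogen on a saturated chain carbon, five bonds along the chain from a carbonyl carbon. Among the measured compounds shown here, only one measured step bears on this change: hexyl entering at that same place gave an at least 3.7-fold lower number from compound 1 to compound 2 (0.57 log units; beyond the scatter). Dodecyl is the larger group, so a further move in the same direction seems likely, although a single step cannot show how far the trend runs. The expected step is an at least 10-fold lower number from compound 1 to compound 3 (1.00 log units; beyond the scatter), towards a lower number in this assay. For compound 3 the estimated value is 150 ug/mL. The expected range for this estimate runs from 40 ug/mL to 700 ug/mL.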

Compound 3, half-maximal effective concentration: 30 ug/mL
Compound 3: middle estimate off by 5.0-fold (0.70 log units), on the high side, and the stated range ends above it.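

The earlier pair left open whether lengthening the chain would keep having an effect, and compound 3 shows that it does in this assay: the number keeps falling well past compound 2 (a 13-fold lower number from compound 2 to compound 3 (1.12 log units; beyond the scatter)). Over the whole change, dodecyl in place of hydrogen gives the largest step shown (an at least 50-fold lower number from compound 1 to compound 3 (1.69 log units; beyond the scatter)), and this step has only a bound on its size, as compound 1 gives a limit and not a number: (the limit of > 1500 ug/mL in this assay, at which 1 of the 3 values shown sits). The added hexyl thus still has a clear effect when it enters on the chain of compound 2, so the effect is not confined to the first few chain carbons.

A longer chain could lower the number further or level off. An amine or a carboxylic acid at the far end of the dodecyl-extended chain also remains an open case.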